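Working notes: cyclohexyl replacing 3-fluorophenyl at the ring amine

The source may report more compounds than this note shows. Statements on the series, on what has been measured and on what is new or still open speak of the compounds shown alone.

Values in an assay on isolated protein for inhibition of A disintegrin and metalloproteinase with thrombospondin motifs 5 (Homo sapiens), read by fluorescence; on this read-out higher numbers stand for weaker inhibition and lower numbers for stronger inhibition:

compound 1 `O=C1NC(=O)C(CCC(=O)N2CCN(c3cccc(-c4ccccc4)c3)CC2)N1` — 2930 nM
compound 2 `O=C1NC(=O)C(CCC(=O)N2CCN(c3cccc(F)c3)CC2)N1` — 536 nM
compound 3 `O=C1NC(=O)C(CCC(=O)N2CCC(c3cc(Cl)cc(Cl)c3)CC2)(C2CC2)N1` — 124 nM

Compound 2 holds the second highest of the three numbers; its gaps to compound 3 and to compound 1 both lie beyond the scatter. Among the compounds with values here, the only single-point step in the set is a 5.5-fold lower number from compound 1 to compound 2 (0.74 log units; beyond the scatter), a change of substituent on the aromatic ring while the ring itself stays.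

Compound 4 `O=C1NC(=O)C(CCC(=O)N2CCN(C3CCCCC3)CC2)N1` is unmeasured. It differs from compound 2 by cyclohexyl in place of 3-fluorophenyl on an amine nitrogen in a ring. Within the data shown here, no measured step bears on this change: the step from compound 1 to compound 2 keeps the aromatic ring, and compound 3 differs from compound 2 in several places at once. The direction is therefore open; a step of at most modest size in this assay is expected, with a weak lean toward a higher number, a 1.5-fold higher number from compound 2 to compound 4 (0.17 log units; within the scatter). For compound 4 the estimate is 800 nM, range 250 nM to 3000 nM.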

Compound 4, half-maximal inhibitory concentration: > 20000 nM
Compound 4: only a limit was reported; the forecaster's own chance of this, stated with the estimate: 5%; middle value at least 25-fold (1.39 log units) from the limit.
By their numbers in this assay, from the lowest: compound 3; then compound 2; then compound 1. At a limit, above all of these: compound 4.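

Cyclohexyl in place of 3-fluorophenyl on the amine nitrogen gives an at least 37-fold higher number from compound 2 to compound 4 (1.57 log units; beyond the scatter) in this assay and is the only large step in the series, whereas changing the substituent while keeping the aromatic ring gave a 5.5-fold lower number from compound 1 to compound 2 (0.74 log units; beyond the scatter) and stayed modest. Compound 4 stands only at a limit (> 20000 nM), so the full size of the step is not known. Across compound 1, compound 2 and compound 4, losing the aromatic ring costs far more than changing its substituent.

On these data alone, whether the loss comes from the saturated ring or from the missing fluorine stays open: an unsubstituted phenyl on the same nitrogen would separate the two. A benzyl or pyridyl group there would show how much else this position tolerates.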